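Notes on compound 4, the deschloro analogue of compound 1

The compounds below may be only part of what the source reports. "The series", "measured", "known", "first", "only" and "open" are said of these compounds alone.

Three compounds have numbers in a functional assay on MDA-MB-231 cells (Homo sapiens) for cytotoxicity, read by sulforhodamine B assay, with a stated time of 48 h; on this read-out lower numbers stand for stronger inhibition of growth and higher numbers for weaker inhibition of growth. Compound 1 `Cc1ccc2nc(/N=C3\C(=O)N(CN(C)C)c4cccc(Cl)c43)sc2c1` gives 10900 nM and stands lowest of the three. Compound 2 `O=C1C(=O)N(CN2CCCCC2)c2cccc(Cl)c21` gives 26500 nM, a somewhat higher number than compound 1. Compound 3 `Cc1ccc2nc(/N=C3\C(=O)N(CN4CCCCC4)c4cccc(Cl)c43)sc2c1` gives 55800 nM, the highest of the set. Among the compounds with values here, the one step between measured compounds that differ in a single place is a 5.1-fold higher number from compound 1 to compound 3 (0.71 log units; beyond the scatter).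

Compound 4 `Cc1ccc2nc(/N=C3\C(=O)N(CN(C)C)c4ccccc43)sc2c1` has not been measured. It differs from compound 1 in one place: hydrogen in place of chloro on an aromatic carbon. Within the data shown here, no measured pair in the set changes this aromatic position, so the step from compound 1 to compound 3 does not bear on it directly; it only shows that changes away from the core can move the number well beyond the scatter. Compound 2 and compound 3 both keep the chloro, so they give no reading on its removal either.

With nothing in the data to anchor the direction, the expectation is set near compound 1, allowing for a moderate shift in either direction, and a loss of growth inhibition is judged somewhat more likely than a gain. The estimated step is a 1.8-fold higher number from compound 1 to compound 4 (0.26 log units; within the scatter). Compound 4 is therefore expected to give about 20000 nM in this assay, with a likely range from 7000 nM to 60000 nM.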

Compound 4, concentration for 50% growth inhibition: 19200 nM
Beside the measured number, compound 4's estimate is 1.0-fold (0.02 log units) above it; measured number inside the range.
By their numbers in this assay, from the lowest: compounds 1, 4 and 2 (each within the scatter of the next, the first and the last beyond it); then compound 3.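

In this assay, hydrogen in place of chloro on this aromatic carbon, ortho to a fused ring, gives a 1.8-fold higher number from compound 1 to compound 4 (0.25 log units; within the scatter) and so stays within the usual scatter of repeated measurements, which means that the chloro is not needed to keep the number of compound 1 in this read-out. Within the data shown here, this is the first reading at this position, and it contrasts with the only other step from compound 1, on the saturated chain carbon, which gives a 5.1-fold higher number from compound 1 to compound 3 (0.71 log units; beyond the scatter) and is printed as beyond the scatter; in this pair, therefore, the change on the chain carbon counts for more than the loss of chloro. Nothing on hand explains the size of the step at the aromatic carbon, or shows why it stays within the scatter.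

On these data alone, whether hydrogen in place of chloro reads the same way with piperidin-1-yl on the chain carbon, as in compound 3, remains open, since a single pair cannot show this. Also open, as far as these compounds go, is how fluoro, bromo, methoxy or an amine on this aromatic carbon would read against compound 1 and compound 4.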